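Triazole series: aryl substituent on the ring nitrogen

The source may hold more compounds than are shown below. What is called first, only, known or untested is meant among the compounds shown, and "the series" means these compounds.

Three compounds share one core, measured in a functional assay on A549 cells (Homo sapiens) for inhibition, read by MTT assay, with a stated time of 24 h; a higher number here means a weaker inhibitor, a lower number a stronger inhibitor. Compound 1 `CC1(C)[C@H]2CC[C@]1(C)N(Cc1cn(-c3ccccc3Br)nn1)C(=O)C2` gives 130 nM; compound 2 `CC1(C)[C@H]2CC[C@]1(C)N(Cc1cn(-c3ccc(C#N)cc3)nn1)C(=O)C2` gives 140 nM; compound 3 `CC1(C)[C@H]2CC[C@]1(C)N(Cc1cn(-c3ccc(Br)cc3)nn1)C(=O)C2` gives 80 nM. Compound 1 stands second highest of the three numbers, nearest to compound 2 and furthest from compound 3, with every gap within the scatter.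

Compound 4 `Cc1ccc(-n2cc(CN3C(=O)C[C@@H]4CC[C@@]3(C)C4(C)C)nn2)cc1` differs from compound 1 in one place: 4-methylphenyl in place of 2-bromophenyl on an aromatic nitrogen.

For the measured compounds named here, two measured steps bear on this. The step of a 1.6-fold lower number from compound 1 to compound 3 (0.21 log units; within the scatter) also replaces 2-bromophenyl by a 4-substituted phenyl, and the step of a 1.1-fold higher number from compound 1 to compound 2 (0.03 log units; within the scatter) does the same with a 4-cyanophenyl; both lie within the scatter, as does a 1.8-fold lower number from compound 2 to compound 3 (0.24 log units; within the scatter). Going by the values given here, nothing measured so far exceeds the scatter, so a 4-methylphenyl is not expected to move this assay beyond it either. The expected step is a 1.2-fold lower number from compound 1 to compound 4 (0.07 log units; within the scatter). Compound 4 is therefore estimated at 110 nM, with a range from 50 nM to 250 nM.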

Compound 4, half-maximal inhibitory concentration: 400 nM
For compound 4 the middle estimate is 3.6-fold (0.56 log units) below the measured one; measured number outside the range, above it.
By their numbers in this assay, from the lowest: compounds 3, 1 and 2 (each within the scatter of the next); then compound 4.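

In this assay the aryl group on the aromatic nitrogen now shows steps beyond the scatter: 4-methylphenyl in place of 2-bromophenyl gives a 3.1-fold higher number from compound 1 to compound 4 (0.49 log units; beyond the scatter) and methyl in place of bromo gives a 5.0-fold higher number from compound 3 to compound 4 (0.70 log units; beyond the scatter) while methyl in place of cyano gives a 2.9-fold higher number from compound 2 to compound 4 (0.46 log units; beyond the scatter) on this read-out. The identity of the group on the phenyl ring therefore matters, since 4-bromophenyl and 4-cyanophenyl stay within the scatter of each other and of 2-bromophenyl, and 4-methylphenyl alone stands apart. No available evidence accounts for this separation.

From the compounds shown here alone, the separation rests on compound 4 alone, so it remains open whether an ethyl, a methoxy or an amine on the phenyl ring would track with methyl or with bromo and cyano. Also open, going by these compounds, is whether 2-methylphenyl would give the number of compound 4 or that of compound 1.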